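Benzyl to isopentyl in a weakly active series

A few compounds are considered here, and "the series" means these few. Any claim that something is new, unique, unknown or untested is made for them only; others in the source may bear on it.

In a functional assay on K562 cells (Homo sapiens) for inhibition, read by MTT assay, with a stated time of 48 h (a lower number here means a stronger inhibitor, a higher number a weaker inhibitor), compound 1 `CCCCCNc1cc(C)n(Cc2ccccc2)c(=O)c1` gives 140000 nM, and compound 2 `Cc1cc(NCc2ccc(Cl)cc2)cc(=O)n1CCC(C)C` gives 224000 nM. Compound 3 `Cc1cc(NCCC(C)C)cc(=O)n1Cc1ccccc1` gives > 300000 nM, which is a limit and not a number. Going by the values given here, compound 3 is the one compound that stands at the limit of > 300000 nM in this assay, at which 1 of the 3 values shown sits.

The next compound, compound 4 `Cc1cc(NCCC(C)C)cc(=O)n1CCC(C)C`, keeps the isopentyl amine chain of compound 3 and changes the other substituent: isobutyl in place of phenyl on a saturated chain carbon bound to an aromatic nitrogen. Put another way, benzyl gives way to isopentyl, on a saturated chain carbon bound to an aromatic nitrogen.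

Among the compounds with values here, only one measured step exists, and it lies elsewhere in the molecule, with isopropyl in place of propyl on the amine chain: an at least 2.1-fold higher number from compound 1 to compound 3 (0.33 log units; beyond the scatter). It shows that this series can respond to a small change in a chain, but it does not measure the present swap. Compound 4 takes up the isopentyl group already carried by compound 2, and compound 2 gives 224000 nM, though with a different amine substituent.

No step beyond the scatter is therefore expected, and compound 4 may well also read as a limit. The expected change is a step that the limit leaves unreadable from compound 3 to compound 4. Compound 4 is estimated at 320000 nM, with an expected range of 180000 nM to 600000 nM.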

Compound 4, half-maximal inhibitory concentration: 128000 nM
Beside the measured number, compound 4's estimate is 2.5-fold (0.40 log units) above it, outside the stated range (below it).
By their numbers in this assay, from the lowest: compounds 4, 1 and 2 (each within the scatter of the next). At a limit, above all of these: compound 3.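

Going by these compounds alone, with the isopentyl amine chain held constant, the exchange of benzyl for isopentyl at this position gives, in this assay, an at least 2.3-fold lower number from compound 3 to compound 4 (0.36 log units; beyond the scatter), the first measured step at a saturated chain carbon bound to an aromatic nitrogen. The other new step lies on the amine side, where isobutyl stands in place of 4-chlorophenyl on a saturated chain carbon bound to a nitrogen on an aromatic ring, and it reads a 1.8-fold lower number from compound 2 to compound 4 (0.24 log units; within the scatter), so an aromatic ring leaving for isobutyl registers beyond the scatter at one place and within it at the other, on this single pair of steps. Within the data shown here, compound 3 remains the only compound at a limit: the limit of > 300000 nM in this assay, at which 1 of the 4 values shown sits.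

The step at this position is shown only on the isopentyl amine chain, so whether it carries over to another amine substituent stays open. Also open, on these data alone, is how a longer chain, a cyclohexylmethyl group or a carboxylic acid at the end of the chain would read at this position in this assay.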